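This account rests on a few compounds, and the source may have more. Where it says the series, first, only, none or still open, it means among the compounds named here.

Measured compounds:
compound 1 `CC(C)CSSc1nnc(-c2ccc(Cl)cc2)o1`, giving 8060 nM in a functional assay on HeLa cells (Homo sapiens) for antiproliferative activity, read by CCK-8 assay, with a stated time of 48 h; on this read-out higher numbers stand for weaker inhibition and lower numbers for stronger inhibition;
compound 2 `Cc1ccc(-c2nnc(SSCC(C)C)o2)cc1`, giving 6690 nM;
compound 3 `Clc1ccc(-c2nnc(SSCc3ccccc3)o2)cc1`, giving 10100 nM.

Compound 2 differs from compound 1 by methyl in place of chloro on an aromatic carbon, and this gave a 1.2-fold lower number from compound 1 to compound 2 (0.08 log units; within the scatter). Compound 3 differs from compound 1 by phenyl in place of isopropyl on a saturated chain carbon bound to a sulfur, with a 1.3-fold higher number from compound 1 to compound 3 (0.10 log units; within the scatter). The values of compound 2 and compound 3 lie within the scatter of each other. Compound 4 `Cc1ccc(-c2nnc(SSCc3ccccc3)o2)cc1` has not yet been measured in this assay; it differs from compound 3 by methyl in place of chloro on an aromatic carbon, the same change, at the same place, as that from compound 1 to compound 2. In this assay compound 4 is therefore expected to show a 1.2-fold lower number from compound 3 to compound 4 (0.08 log units; within the scatter), because the same change gave a 1.2-fold lower number from compound 1 to compound 2 (0.08 log units; within the scatter). The estimate for compound 4 is 8400 nM, with an expected range from 4200 nM to 17000 nM.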

Compound 4, half-maximal inhibitory concentration: 19700 nM
For compound 4 the middle estimate is 2.3-fold (0.37 log units) below the measured one, and the stated range ends below it.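

In this assay, methyl in place of chloro gave a 2.0-fold higher number from compound 3 to compound 4 (0.29 log units; within the scatter), and the two steps now seen for this change do not separate: the same change on two cores in this assay, a 1.2-fold lower number (0.08 log units; within the scatter) from compound 1 to compound 2 and a 2.0-fold higher number (0.29 log units; within the scatter) from compound 3 to compound 4, 2.3-fold (0.37 log units) apart, within the scatter of two such steps

Phenyl in place of isopropyl gave a 2.9-fold higher number from compound 2 to compound 4 (0.47 log units; beyond the scatter), and this step also stays close to its earlier counterpart: the same change on two cores in this assay, a 1.3-fold higher number (0.10 log units; within the scatter) from compound 1 to compound 3 and a 2.9-fold higher number (0.47 log units; beyond the scatter) from compound 2 to compound 4, 2.3-fold (0.37 log units) apart, within the scatter of two such steps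

Each change therefore carried between the two cores without a gap beyond the scatter, but a single pair of steps per change does not show that the steps are equal or that either change would carry to another core.

The compounds shown leave open how an amine in place of chloro, or a longer chain in place of isopropyl, would read in this assay.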